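The compounds below may be only part of what the source reports. "The series", "measured", "known", "first", "only" and "open" are said of these compounds alone.

Values so far in an ADME assay on MDA-MB-231 cells (Homo sapiens) for inhibition, read by MTT assay, with a stated time of 24 h (a higher number here means a weaker inhibitor, a lower number a stronger inhibitor), for the measured compounds
- compound 1 `CC(C)=CCC[C@H](C)c1ccc(C)c(CNCCO)c1O` gives > 20000 nM as a limit
- compound 2 `CC(C)=CCC[C@H](C)c1ccc(C)c(CNCCCCCO)c1O` gives > 20000 nM as a limit

Compound 2 gives > 20000 nM in this assay as a limit and not a number. Among the measured compounds shown here, the one measured change is a step that the two limits leave unreadable from compound 1 to compound 2 and offers no size to build on. All that stands is the limit of > 20000 nM in this assay, at which 2 of the 2 values shown sit, and nothing more. Compound 3 `CC(C)=CCC[C@H](C)c1ccc(C)c(CNCCCCC(=O)O)c1O` differs from compound 2 in one place with carboxy in place of hydroxymethyl on a saturated chain carbon, four bonds along the chain from an amine nitrogen and carries carboxy in place of hydroxymethyl on a saturated chain carbon, four bonds along the chain from an amine nitrogen. The estimated change is a step that the limit leaves unreadable from compound 2 to compound 3 and no step beyond the scatter is expected in either direction. For compound 3 the expected value is 25000 nM within a range of 12000 nM to 50000 nM and again a limit is likely.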

Compound 3, half-maximal inhibitory concentration: > 20000 nM
Compound 3 was reported as a limit; the forecaster's own chance of this, stated with the estimate: 80%; the middle value lies beyond the limit too.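

No step among compound 1, compound 2 and compound 3 can be read in this assay, since each is reported only as a limit: the limit of > 20000 nM in this assay, at which 3 of the 3 values shown sit.

The compounds shown leave open whether exchanging hydroxymethyl for carboxy changes inhibition at all, and at what concentration any of the three would reach half-maximal inhibition.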